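This account rests on a few compounds, and the source may have more. Where it says the series, first, only, none or still open, it means among the compounds named here.

The two measured compounds share one core, `CCCc1cc2ccccc2nc1-c1cc(-c2ccccc2)no1` for compound 1, and differ only on an aromatic carbon. In a functional assay on PC-3 cells (Homo sapiens) for inhibition, read by MTT assay, with a stated time of 24 h (on this read-out lower numbers stand for stronger inhibition and higher numbers for weaker inhibition), compound 1 gives 51300 nM. Compound 2, `CCCc1cc2ccccc2nc1-c1cc(-c2ccc(C)cc2)no1`, carries a methyl in place of hydrogen on that aromatic carbon. In this assay compound 2 gives > 100000 nM, which is a limit of the assay and not a measured number. Going by the values given here, the only measured step is therefore open-ended: an at least 1.9-fold higher number from compound 1 to compound 2 (0.28 log units; that floor lies within the scatter), and it is known only through (the limit of > 100000 nM in this assay, at which 1 of the 2 values shown sits).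

Compound 3, `CCCCCc1cc2ccccc2nc1-c1cc(-c2ccc(C)cc2)no1`, differs from compound 2 by ethyl in place of hydrogen on a saturated chain carbon, three bonds along the chain from an aromatic carbon; cut one bond further out, the same difference reads propyl to pentyl. Among the compounds with values here, no measured step touches this chain, since the one step measured concerns the aromatic carbon, so nothing here sets a direction for lengthening the chain. Because compound 2 already sits at > 100000 nM, compound 3 is expected to land near that limit as well, with no step beyond the scatter foreseen.

Compound 3 is estimated to give 150000 nM, between 50000 nM and 500000 nM. That corresponds to an expected step that the limit leaves unreadable from compound 2 to compound 3.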

Compound 3, half-maximal inhibitory concentration: > 100000 nM
Compound 3: a limit, no number; the forecaster's own chance of this, stated with the estimate: 75%; the middle value is on the limit's open side.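

In this assay compound 3 gives > 100000 nM, which is a limit of the assay and not a number. Going by these compounds alone, no step from compound 2 to compound 3 can be read, since both compounds stop at a limit: the limit of > 100000 nM in this assay, at which 2 of the 3 values shown sit. The compounds shown leave open whether going from propyl to pentyl changes the read-out at all.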